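The compounds below may be only part of what the source reports. "The series", "measured", "known", "first", "only" and "open" are said of these compounds alone.

Measured so far in a functional assay on SK-OV-3 cells (Homo sapiens) for antiproliferative activity, read by MTT assay, with a stated time of 72 h; a lower number here means a stronger inhibitor, a higher number a weaker inhibitor:
- compound 1 `O=C(CCc1cccc2c1B(O)OC2)Nc1cccc(-c2cccc(Cl)c2)c1`: 300 nM
- compound 2 `O=C(CCc1cccc2c1B(O)OC2)Nc1cccc(-c2ccc(OC(F)(F)F)cc2)c1`: 560 nM

In this assay compound 2 stands at 560 nM and compound 1 at 300 nM. These two values lie within the usual scatter of each other, so neither compound can be ranked above the other.

Next in the series is compound 3 `O=C(CCc1cccc2c1B(O)OC2)Nc1cccc(-c2ccc(C(F)(F)F)cc2)c1`, not yet measured. It differs from compound 2 by trifluoromethyl in place of trifluoromethoxy on an aromatic carbon, para to a large group (trifluoromethyl in place of trifluoromethoxy on an aromatic carbon).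

Among the measured compounds shown here, the series holds no measured pair differing in one place, so the data do not size this change directly. No step beyond the scatter is expected in this assay, and neither direction is clearly favoured. The anchor for the expectation is compound 2 at 560 nM.

The expected change is small, with a 1.1-fold lower number from compound 2 to compound 3 (0.05 log units; within the scatter) estimated to stay within the scatter. For compound 3 the estimated value is 500 nM, with an expected range of 200 nM to 1300 nM.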

Compound 3, half-maximal inhibitory concentration: 500 nM
The estimate for compound 3 equals the measured number at the digits printed, and the stated range covers the measured number.
By their numbers in this assay, from the lowest: compounds 1, 3 and 2 (each within the scatter of the next).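

In this assay, among the compounds shown here, the step of a 1.1-fold lower number from compound 2 to compound 3 (0.05 log units; within the scatter) is the first direct one-place reading at this aromatic carbon, para to a large group. Trifluoromethyl in place of trifluoromethoxy removes one oxygen and the one hydrogen-bond acceptor counted for the leaving group, and the step stays within the scatter in this read-out. The wider exchange of 4-(trifluoromethyl)phenyl in place of 3-chlorophenyl, read as a 1.7-fold higher number from compound 1 to compound 3 (0.22 log units; within the scatter), also stays within the scatter, so the three aryl variants shown form one flat group with no order among them, and nothing measured on these compounds accounts for either step.

The compounds shown do not reveal what would move the number beyond the scatter at this position, such as an amine, a carboxylic acid or plain hydrogen in place of trifluoromethyl. As far as these compounds go, the linking amide chain and the shared core stay constant throughout, so the effect of a longer chain or any change to the core remains open.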